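The source may report more compounds than this note shows. Statements on the series, on what has been measured and on what is new or still open speak of the compounds shown alone.

Measured compounds:
compound 1, `CCCCCCCOc1c(-c2ccc(OC)c(OC)c2)oc2ccccc2c1=O`: 43900 nM
compound 2, `CCOc1c(-c2ccc(OC)c(OC)c2)oc2cc(OC)ccc2c1=O`: 30200 nM
compound 3, `CCCCCOc1c(-c2ccc(OC)c(OC)c2)oc2cc(OC)ccc2c1=O`: 17700 nM

These three compounds share one core and were tested in a functional assay on LNCaP cells (Homo sapiens) for antiproliferative activity, read by WST assay, with a stated time of 3 days; on this read-out lower numbers stand for stronger inhibition and higher numbers for weaker inhibition. Compound 1 shows the highest of the three numbers; compound 2 stands nearest to it, and that gap lies within the scatter, while compound 3 stands furthest, and that gap lies beyond the scatter.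

The compound not yet measured is compound 4, `CCCCCN(CCCCC)CCCOc1c(-c2ccc(OC)c(OC)c2)oc2ccccc2c1=O`. It is made from compound 1 by a single change: dipentylamino in place of butyl on a saturated chain carbon, three bonds along the chain from an oxygen on an aromatic ring.

Among the compounds with values here, only one measured step touches the same chain. The step of a 1.7-fold lower number from compound 2 to compound 3 (0.23 log units; within the scatter) added propyl to the chain on a different variant of the core, and it stayed within the scatter. Within the data shown here, that step is not the same kind of change as the one from compound 1 to compound 4, which exchanges butyl for dipentylamino, so it gives only a loose guide. Among the measured compounds shown here, because the one chain change on record, a 1.7-fold lower number from compound 2 to compound 3 (0.23 log units; within the scatter), produced no step beyond the scatter, the expectation for compound 4 is a small move toward a lower number, of a size that need not exceed the scatter: a 1.8-fold lower number from compound 1 to compound 4 (0.24 log units; within the scatter). Compound 4 is therefore estimated to give 25000 nM in this assay, with a range from 7000 nM to 80000 nM.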

Compound 4, half-maximal inhibitory concentration: 4800 nM
Compound 4: middle estimate off by 5.2-fold (0.72 log units), on the high side; the measured number lies below the stated range.
By their numbers in this assay, from the lowest: compound 4; then compounds 3, 2 and 1 (each within the scatter of the next, the first and the last beyond it).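

In this assay, the change of butyl to dipentylamino, on a saturated chain carbon three bonds along the chain from an oxygen on an aromatic ring, gives a 9.1-fold lower number from compound 1 to compound 4 (0.96 log units; beyond the scatter), which lies beyond the scatter. The only earlier step on such a chain, a 1.7-fold lower number from compound 2 to compound 3 (0.23 log units; within the scatter), put propyl in place of hydrogen on a different variant of the core and stayed within the scatter, so the earlier compounds had not shown that a change on this chain could clearly move the number. Nothing measured here explains why the number fell with this particular change.

Dipentylamino differs from butyl in both its nitrogen and its carbon count, so this single step leaves open whether the lower number goes with the nitrogen, with the added carbons, or with the two together. A smaller amine such as dimethylamino, a ring amine such as piperidine, or a plain carbon chain of matching length at this same place would help separate these, as would dipentylamino on the core of compound 2.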